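Replacing Methoxy with Tert-Butyl in Compound 4

The source may hold more compounds than are shown below. What is called first, only, known or untested is meant among the compounds shown, and "the series" means these compounds.

Measured so far in an ADME assay on L6 cells (Rattus norvegicus) for cytotoxicity, read by resazurin assay, with a stated time of 70 h; on this read-out lower numbers stand for stronger inhibition and higher numbers for weaker inhibition:
- Compound 1 `CC(=O)Oc1ccc2c(c1)C(C)=CC(C)(C)N2Cc1ccccc1`: 24000 nM
- Compound 2 `CC(=O)Oc1ccc2c(c1)C(C)=CC(C)(C)N2Cc1ccc(C#N)cc1`: 29000 nM
- Compound 3 `COc1ccc(CN2c3ccc(OC(C)=O)cc3C(C)=CC2(C)C)cc1`: 15000 nM

Compound 3, at 15000 nM, stands within the usual scatter of repeated measurements of both other compounds, so the three cannot be ranked on these numbers. The next change gives compound 4 `CC(=O)Oc1ccc2c(c1)C(C)=CC(C)(C)N2Cc1ccc(C(C)(C)C)cc1`, with tert-butyl in place of methoxy on an aromatic carbon, para to a large group (tert-butyl in place of methoxy on an aromatic carbon).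

Three measured changes at this place bear on it. Cyano in place of hydrogen gave a 1.2-fold higher number from compound 1 to compound 2 (0.08 log units; within the scatter). Methoxy in place of hydrogen gave a 1.6-fold lower number from compound 1 to compound 3 (0.20 log units; within the scatter). Methoxy in place of cyano gave a 1.9-fold lower number from compound 2 to compound 3 (0.29 log units; within the scatter).

For the measured compounds named here, no tert-butyl compound has been measured yet, so the guide is limited. With even the largest of these steps being a 1.9-fold lower number from compound 2 to compound 3 (0.29 log units; within the scatter), no step beyond the scatter is expected in this assay. The estimated step is a 1.1-fold higher number from compound 3 to compound 4 (0.03 log units; within the scatter). For compound 4 the expected value is 16000 nM, with an estimated range from 7000 nM to 33000 nM.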

Compound 4, half-maximal inhibitory concentration: 9000 nM
Compound 4: the middle estimate sits 1.8-fold (0.25 log units) above what was measured, within the range that was stated.
By their numbers in this assay, from the lowest: compounds 4, 3, 1 and 2 (each within the scatter of the next, the first and the last beyond it).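

In this assay, for the compounds shown here, this position had given only steps within the scatter, and tert-butyl is the first group here to give steps beyond it, both modest (a 3.2-fold lower number from compound 2 to compound 4 (0.51 log units; beyond the scatter)) and (a 2.7-fold lower number from compound 1 to compound 4 (0.43 log units; beyond the scatter)). The comparison with methoxy stays within the scatter (a 1.7-fold lower number from compound 3 to compound 4 (0.22 log units; within the scatter)), so these two groups cannot be told apart on these numbers, even though tert-butyl separates from both hydrogen and cyano. No measurement at hand explains why the numbers shift at this position.

The compounds shown carry only hydrogen, cyano, methoxy or tert-butyl at this place, so it remains open how an amine, a carboxylic acid or a longer alkyl chain would read there. Also open, as far as these compounds go, is whether the same order of groups would hold on a different core.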